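From methoxy to (oxiran-2-yl)methoxy

The source may hold more compounds than are shown below. What is called first, only, known or untested is meant among the compounds shown, and "the series" means these compounds.

In a functional assay on DU-145 cells (Homo sapiens) for cytotoxicity (a lower number here means a stronger inhibitor of growth, a higher number a weaker inhibitor of growth), compound 3 `COc1ccc(C2=C(c3ccc(SC)cc3)CC3CCCN3C2=O)cc1` gives 900 nM. That lies within the scatter of compound 1 `CSc1ccc(C2=C(c3ccc(C)c(C)c3)C(=O)N3CCCC3C2)cc1` at 500 nM, and far from compound 2 `CSc1ccc(C2=C(c3ccc(O)c(O)c3)C(=O)N3CCCC3C2)cc1` at 60000 nM. Compound 4 `CSc1ccc(C2=C(c3ccc(OCC4CO4)cc3)C(=O)N3CCCC3C2)cc1` differs from compound 3 in one place, (oxiran-2-yl in place of hydrogen on a saturated chain carbon bound to an oxygen on an aromatic ring), which turns methoxy into (oxiran-2-yl)methoxy. Among the measured compounds shown here, no measured step tests this group directly, but three steps change the same aromatic substituent. The step of a 1.8-fold higher number from compound 1 to compound 3 (0.26 log units; within the scatter) stayed small, while a 120-fold higher number from compound 1 to compound 2 (2.08 log units; beyond the scatter) and a 67-fold lower number from compound 2 to compound 3 (1.82 log units; beyond the scatter) were large, and both involve the 3,4-dihydroxyphenyl group of compound 2. With no such group present, the expected change is a 1.1-fold higher number from compound 3 to compound 4 (0.05 log units; within the scatter), not beyond the scatter. Compound 4 is estimated at 1000 nM, with an expected range of 300 nM to 3500 nM.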

Compound 4, concentration for 50% growth inhibition: 500 nM
Compound 4: the middle estimate sits 2.0-fold (0.30 log units) above what was measured; the measured number falls inside the stated range.
By their numbers in this assay, from the lowest: compounds 1, 4 and 3 (each within the scatter of the next); then compound 2.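

In this assay, putting oxiran-2-yl on the saturated chain carbon bound to an oxygen on an aromatic ring gives a 1.8-fold lower number from compound 3 to compound 4 (0.26 log units; within the scatter) and so shows that this position tolerates a three-membered ring holding one hetero atom. The larger (oxiran-2-yl)methoxy group reads the same as methoxy here. Nothing available explains this result. Going by these compounds, whether the ring matters or only the added bulk remains open. A plain propyl chain or an amine in place of oxiran-2-yl would help separate the two.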